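The source may report more compounds than this note shows. Statements on the series, on what has been measured and on what is new or still open speak of the compounds shown alone.

Compound 1 `COc1ccc(Oc2ccc3c(NCCCNCc4cccc(OC)c4O)ccnc3c2)cc1` sits at the top of a small set of three. In a physicochemical assay for solubility, with a stated time of 18 h, at pH 7.4 (on this read-out lower numbers stand for lower solubility and higher numbers for higher solubility), compound 1 gives 14500 nM, level with compound 3 `COc1ccc(Oc2ccc3c(NCCCNCc4ccco4)ccnc3c2)cc1`, which in this assay gives 14500 nM. Compound 2 `COc1ccc(F)cc1CNCCCNc1ccnc2cc(CC(C)C)ccc12`, built on a different core, gives a lower number in this assay at 4200 nM. Among the compounds with values here, the one step measured within the set, no change at the digits printed from compound 1 to compound 3 (within the scatter), runs at the far end of the chain from the aryl ether and stays within the scatter.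

Compound 4 `COc1cccc(CNCCCNc2ccnc3cc(Oc4cccc(N(C)C)c4)ccc23)c1O` differs from compound 1 at the ether oxygen instead: 3-(dimethylamino)phenyl in place of 4-methoxyphenyl on an oxygen on an aromatic ring. Within the data shown here, no measured step touches that position, so the only guidance is general: the single known change to compound 1 moved nothing, and compounds 1 and 3 hold the same number despite different groups on the chain. The expectation is therefore for a step of a 1.0-fold lower number from compound 1 to compound 4 (0.02 log units; within the scatter), no shift beyond the scatter, in this assay. Compound 4 is estimated at 14000 nM, with a range from 5000 nM to 40000 nM.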

Compound 4, solubility: 14500 nM
Estimate against measurement, compound 4: 1.0-fold (0.02 log units) below, within the range that was stated.
By their numbers in this assay, from the lowest: compound 2; then compounds 1, 3 and 4 (each within the scatter of the next).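

Within the data shown here, this is the first measured step at the group on the ether oxygen: in this assay, 3-(dimethylamino)phenyl in place of 4-methoxyphenyl gives no change at the digits printed from compound 1 to compound 4 (within the scatter), so this exchange on an oxygen on an aromatic ring leaves the read-out within the scatter. The change alters both the substituent and where it sits on the ring, and this single step cannot separate the two. No supporting evidence is available to explain why the read-out holds at this position.

What the compounds shown leave open is whether the read-out would hold for a carboxylic acid or a primary amine on that phenyl ring, or for a plain phenyl carrying neither group. Also open, going by these compounds, is whether 3-(dimethylamino)phenyl and furan-2-yl would behave the same way together in a single compound.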